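The compounds below may be only part of what the source reports. "The series", "measured", "known", "first", "only" and "open" are said of these compounds alone.

Measured so far in a functional assay on HeLa cells (Homo sapiens) for cytotoxicity, read by MTT assay, with a stated time of 24 h; a higher number here means a weaker inhibitor, a lower number a stronger inhibitor:

Compound 1 `C[C@H](Nc1nc2cc(Cl)c(F)cc2s1)c1ccccc1` gives 58900 nM.
Compound 2 `CCCCCC[C@@H](C)NC(=S)Nc1ccc(F)c(Cl)c1` gives 49100 nM.
Compound 3 `CCCCCC[C@@H](C)Nc1nc2cc(Cl)c(F)cc2s1` gives 48000 nM.

Compound 1 has the largest of the three numbers in this assay, yet its gaps to compound 2 and to compound 3 both lie within the scatter of repeated measurements, so the three cannot be told apart on these numbers.

Compound 4 `CC[C@H](Nc1nc2cc(Cl)c(F)cc2s1)c1ccccc1` has not been measured. It differs from compound 1 in one place: methyl in place of hydrogen on a saturated chain carbon, two bonds along the chain from an aromatic carbon and a nitrogen on an aromatic ring. Going by the values given here, no pair of measured compounds shows this kind of step, so its size is not known from what is measured here. A single added carbon on the chain is a small change, and all three measured compounds sit close together, so for this assay the expected step from compound 1 to compound 4 is a 1.3-fold lower number from compound 1 to compound 4 (0.12 log units; within the scatter), which is no more than the scatter. Compound 4 is therefore estimated at 45000 nM in this assay, with a plausible range from 20000 nM to 110000 nM.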

Compound 4, half-maximal inhibitory concentration: 53300 nM
Compound 4: the middle estimate sits 1.2-fold (0.07 log units) below what was measured, within the range that was stated.
By their numbers in this assay, from the lowest: compounds 3, 2, 4 and 1 (each within the scatter of the next).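

In this assay, replacing hydrogen with methyl on this saturated chain carbon, which turns the methyl group into an ethyl group, gives a 1.1-fold lower number from compound 1 to compound 4 (0.04 log units; within the scatter), so the two compounds cannot be told apart. Going by these compounds alone, this is the first pair in the set that differs in only one place, and it shows that, in this one case, adding a single carbon at this position has no effect that the assay can detect. No supporting evidence is available to explain this result.

From the compounds shown here alone, whether a longer chain, such as propyl or butyl, or an amine on this same carbon would give a step beyond the scatter remains open. One pair also cannot show whether methyl in place of hydrogen would behave the same way at other positions on the chain.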